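A few compounds are considered here, and "the series" means these few. Any claim that something is new, unique, unknown or untested is made for them only; others in the source may bear on it.

Going by the values given here, in a functional assay on CCRF-CEM cells (Homo sapiens) for inhibition, read by cell counting, with a stated time of 72 h (on this read-out higher numbers stand for weaker inhibition and lower numbers for stronger inhibition), compound 3 (`CCN(CC)CN1C(=O)/C(=N/NC(=S)Nc2ccc(OC)cc2)c2cc(Cl)ccc21`) gives 6900 nM and stands between compound 2 (`CCN(CC)CN1C(=O)/C(=N/NC(=S)Nc2ccc(OC)cc2)c2ccccc21`) at 1900 nM and compound 1 (`CCN(CC)CN1C(=O)/C(=N/NC(=S)Nc2ccccc2)c2cc(Cl)ccc21`) at 40000 nM on the numbers so far. Compound 4 (`CCN(CC)CN1C(=O)/C(=N/NC(=S)Nc2ccc(Cl)cc2)c2cc(Cl)ccc21`) carries chloro in place of methoxy on an aromatic carbon, para to a large group (chloro in place of methoxy on an aromatic carbon). The nearest evidence is the modest step on gaining that methoxy (a 5.8-fold lower number from compound 1 to compound 3 (0.76 log units; beyond the scatter)). Chloro in place of hydrogen elsewhere on the shared core (a 3.6-fold higher number from compound 2 to compound 3 (0.56 log units; beyond the scatter)) is also modest but bears only indirectly. No chloro at this place has been measured. A modest step toward a higher number is therefore expected in this assay (a 1.6-fold higher number from compound 3 to compound 4 (0.20 log units; within the scatter)). Compound 4 is estimated at 11000 nM (range 3000 nM to 38000 nM).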

Compound 4, half-maximal inhibitory concentration: > 125000 nM
Compound 4: no number, only a limit (the forecaster's own chance of this, stated with the estimate: 5%); middle value at least 11-fold (1.05 log units) away from the limit.
By their numbers in this assay, from the lowest: compound 2; then compound 3; then compound 1. At a limit, above all of these: compound 4.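

In this assay compound 4 gives > 125000 nM, which is a limit of the assay and not a number. Going by these compounds alone, the group at this place on the aromatic ring matters far more than the earlier compounds suggested, with chloro in place of methoxy giving an at least 18-fold higher number from compound 3 to compound 4 (1.25 log units; beyond the scatter). Chloro and methoxy also move the number in opposite directions from hydrogen: methoxy gives a 5.8-fold lower number from compound 1 to compound 3 (0.76 log units; beyond the scatter), whereas chloro gives an at least 3.1-fold higher number from compound 1 to compound 4 (0.49 log units; beyond the scatter).

As far as these compounds go, the true size of the chloro step remains open, since only a limit is available for compound 4. An amine or a hydroxyl at this place also remains untested among the compounds shown, so it is open whether the lower number seen with methoxy extends to other groups.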